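The source may report more compounds than this note shows. Statements on the series, on what has been measured and on what is new or still open speak of the compounds shown alone.

Within the data shown here, compound 1 `O=c1ccc(-c2ccc3cn[nH]c3c2)cn1Cc1ccccc1C(F)(F)F` gives 133 nM in an assay for inhibition of MAP kinase-interacting serine/threonine-protein kinase 1 (Homo sapiens), read by luminescence and ADP-Glo, with a stated time of 2 h (a lower number here means a stronger inhibitor, a higher number a weaker inhibitor), the only number among the values shown. Compound 2 `Cn1ncc2ccc(-c3ccc(=O)n(Cc4ccccc4)c3)cc21` reaches only a limit in this assay, > 2000 nM, so no number is known for it. Compound 3 `O=c1ccc(-c2ccc3cn[nH]c3c2)cn1Cc1ccccc1F` carries fluoro in place of trifluoromethyl on an aromatic carbon. Among the measured compounds shown here, no measured pair differs in one place, so the size of this step is untested; a modest loss of inhibition in this assay is expected, though it could still fall within the scatter. For compound 3 the estimate is 300 nM, between 100 nM and 900 nM. This expected step amounts to a 2.3-fold higher number from compound 1 to compound 3 (0.35 log units; beyond the scatter).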

Compound 3, half-maximal inhibitory concentration: 47 nM
For compound 3 the middle estimate is 6.4-fold (0.81 log units) above the measured one, and the stated range ends above it.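

In this assay, fluoro in place of trifluoromethyl gives a 2.8-fold lower number from compound 1 to compound 3 (0.45 log units; beyond the scatter). Among these compounds, this shows that trifluoromethyl is not required on this aromatic carbon, and that inhibition here changes with the group at this position, a point that no earlier pair could test. Nothing measured here explains the gain. The compounds shown leave open how a chloro or methoxy group on this carbon would compare with fluoro. They also leave open whether fluoro would keep its effect on another carbon of the same ring.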